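Pyridin-4-yl Amide on a Cyclopentane Diol: Expected Cytotoxicity

This account rests on a few compounds, and the source may have more. Where it says the series, first, only, none or still open, it means among the compounds named here.

Measured so far:
compound 1 `NC(=O)/C=C/[C@H]1C[C@@H](O)[C@@H](O)C1` — > 250000 nM
compound 2 `CN(C)c1ccc(NC(=O)/C=C/[C@H]2C[C@@H](O)[C@@H](O)C2)cc1` — > 170000 nM

In an ADME assay on S2 cells (Drosophila melanogaster) for cytotoxicity, read by MTT assay (on this read-out lower numbers stand for an effect already at smaller amounts and higher numbers for an effect only at larger amounts of compound), compound 1 gives > 250000 nM, which is a limit of the assay rather than a number. Compound 2 gives > 170000 nM, also a limit. Compound 1 therefore stands at the limit of > 250000 nM in this assay, at which 1 of the 2 values shown sits, and the other value shown is the limit of > 170000 nM in this assay, at which 1 of the 2 values shown sits. Among the measured compounds shown here, no step between the measured compounds is available.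

Compound 3 `O=C(/C=C/[C@H]1C[C@@H](O)[C@@H](O)C1)Nc1ccncc1` differs from compound 1 by pyridin-4-yl in place of hydrogen on an amide-type nitrogen. The step of a number no higher from compound 1 to compound 3 (the limit leaves the size open) is expected to be none beyond the scatter. Compound 3 is expected to give 250000 nM, between 100000 nM and 600000 nM.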

Compound 3, half-maximal effective concentration: > 200000 nM
Compound 3: only a limit was reported; the forecaster's own chance of this, stated with the estimate: 80%; the middle value lies beyond the limit too.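

Among the compounds shown here, compound 1 and compound 3 each gave only a limit of the assay, not a number, so no step between them can be read. The compounds shown leave open whether pyridin-4-yl in place of hydrogen on an amide-type nitrogen changes cytotoxicity at all.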